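Quinoline in place of pyridine at the aminomethyl aryl group

The source may report more compounds than this note shows. Statements on the series, on what has been measured and on what is new or still open speak of the compounds shown alone.

Measured compounds:
Compound 1 `N#Cc1ccc(CNc2ccc(-c3c(N)nc(N)nc3COCc3ccccc3)cc2)cc1`: 2.8 nM
Compound 2 `Nc1nc(N)c(-c2ccc(NCc3csc(Cl)c3)cc2)c(COCc2ccccc2)n1`: 6.3 nM
Compound 3 `Nc1nc(N)c(-c2ccc(NCc3ccncc3)cc2)c(COCc2ccccc2)n1`: 21 nM

In an in vitro assay on CHOK cells for displacement of a labelled ligand from growth hormone secretagogue receptor type 1 (Homo sapiens) (a higher number here means a weaker inhibitor, a lower number a stronger inhibitor), compound 3 gives the highest of the three numbers, beyond the scatter from both others: a 3.3-fold higher number from compound 2 to compound 3 (0.52 log units; beyond the scatter) and a 7.5-fold higher number from compound 1 to compound 3 (0.88 log units; beyond the scatter). Compound 4 `Nc1nc(N)c(-c2ccc(NCc3cnc4ccccc4c3)cc2)c(COCc2ccccc2)n1` differs from compound 3 by quinolin-3-yl in place of pyridin-4-yl on a saturated chain carbon bound to a nitrogen on an aromatic ring. Among the compounds with values here, no measured step adds a fused ring at this position; the two steps that end at compound 3 show only that pyridin-4-yl is the weakest of the three groups tried, with a 7.5-fold higher number from compound 1 to compound 3 (0.88 log units; beyond the scatter) being the larger move. The quinolin-3-yl group is therefore expected to move the number down rather than up, by a modest amount, a 2.6-fold lower number from compound 3 to compound 4 (0.42 log units; beyond the scatter). Compound 4 is thus estimated at 8 nM, within 3 nM to 25 nM.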

Compound 4, half-maximal inhibitory concentration: 130 nM
Compound 4: middle estimate off by 16-fold (1.21 log units), on the low side, and the stated range ends below it.
By their numbers in this assay, from the lowest: compound 1; then compound 2; then compound 3; then compound 4.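

In this assay, quinolin-3-yl on this saturated chain carbon gives a 6.2-fold higher number from compound 3 to compound 4 (0.79 log units; beyond the scatter), so the added aromatic ring of carbon only lowers binding instead of improving on pyridin-4-yl. The gaps to the other groups are wider, at a 21-fold higher number from compound 2 to compound 4 (1.31 log units; beyond the scatter) and a 46-fold higher number from compound 1 to compound 4 (1.67 log units; beyond the scatter), which makes compound 4 the weakest of the four. No evidence at hand explains this loss.

From the compounds shown here alone, it remains open whether the loss follows from the second ring or from where the group is attached. Naphthalen-2-yl or quinolin-6-yl at this place would help separate these.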